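A Hydroxy Group on an Inactive Benzylidene Thiosemicarbazide

This account rests on a few compounds, and the source may have more. Where it says the series, first, only, none or still open, it means among the compounds named here.

Compound 1 `CC1=CC[C@H](C(C)(C)NC(=S)NN)CC1` carries the free hydrazide; in a functional assay on UACC-62 cells (Homo sapiens) for inhibition, read by sulforhodamine B assay, with a stated time of 48 h (on this read-out lower numbers stand for stronger inhibition of growth and higher numbers for weaker inhibition of growth), compound 1 gives "not determined" (no result reported). Compound 2 `CC1=CC[C@H](C(C)(C)NC(=S)N/N=C/c2ccccc2)CC1` bears a benzylidene unit in its place. In this assay compound 2 reaches only > 100000 nM, which is a limit of the assay and not a number, as the limit of > 100000 nM in this assay, at which 1 of the 2 values shown sits, shows. Compound 3 `CC1=CC[C@H](C(C)(C)NC(=S)N/N=C/c2ccccc2O)CC1` differs from compound 2 by hydroxy in place of hydrogen on an aromatic carbon. Within the data shown here, no measured pair gives a scale for this change, so the step from compound 2 to compound 3 is expected to stay within the scatter, in no direction. Compound 3 is therefore estimated at 100000 nM (range 25000 nM to 400000 nM). The expected step is a number no higher from compound 2 to compound 3 (the limit leaves the size open), and a limit rather than a number seems the likely report.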

Compound 3, concentration for total growth inhibition: 10800 nM
Compound 3: middle estimate off by 9.3-fold (0.97 log units), on the high side, and the stated range ends above it.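

On the aromatic ring of the benzylidene unit, this position is not indifferent: the change from phenyl to 2-hydroxyphenyl gives an at least 9.2-fold lower number from compound 2 to compound 3 (0.96 log units; beyond the scatter) in this assay, where compound 3 gives 10800 nM. Among these compounds, it is the first single number, and it comes from hydroxy ortho to a large group. Compound 2 stands at a limit and not at a number, so the full size of the step stays unread: the limit of > 100000 nM in this assay, at which 1 of the 3 values shown sits.

The compounds shown do not tell why hydroxy has this effect. Going by these compounds, whether methoxy, an amine or a carboxylic acid on the same carbon would do the same remains open, as does hydroxy elsewhere on the ring.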